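Methyl on the Phenyl Ring: From Furan to Thiophene Core

A few compounds are considered here, and "the series" means these few. Any claim that something is new, unique, unknown or untested is made for them only; others in the source may bear on it.

Measured so far:
compound 1, `C/C(=C\c1cc(-c2ccccc2)co1)C(N)=O`, 3340 nM;
compound 2, `C/C(=C\c1cc(-c2ccc(C)cc2)co1)C(N)=O`, 1630 nM;
compound 3, `C/C(=C\c1cc(-c2ccccc2)cs1)C(N)=O`, 2680 nM.

All three were tested in a functional assay on MCF7 cells (Homo sapiens) for cytotoxicity, read by CCK-8 assay, with a stated time of 24 h; a lower number here means a stronger inhibitor, a higher number a weaker inhibitor. Compound 1 and compound 2 share a core and differ by one change, (methyl in place of hydrogen on an aromatic carbon), which gave a 2.0-fold lower number from compound 1 to compound 2 (0.31 log units; beyond the scatter). Compound 3 has a different core; how its core differs from that of compound 1 is not broken down here, and the two values lie within the scatter of each other.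

Compound 4, `C/C(=C\c1cc(-c2ccc(C)cc2)cs1)C(N)=O`, is not yet measured. It differs from compound 3 by methyl in place of hydrogen on an aromatic carbon, the same change that turned compound 1 into compound 2. Because that earlier change produced a 2.0-fold lower number from compound 1 to compound 2 (0.31 log units; beyond the scatter), a step of similar size is expected here, though on a different core. Compound 4 is therefore estimated to give 1400 nM, between 700 nM and 2800 nM, an expected step of a 1.9-fold lower number from compound 3 to compound 4 (0.28 log units; within the scatter).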

Compound 4, half-maximal inhibitory concentration: > 50000 nM
Compound 4 ended at the assay's limit (the forecaster's own chance of this, stated with the estimate: 2%); at least 35-fold (1.55 log units) between middle value and limit.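

The same methyl change did not carry over from one core to the other in this assay, and the two steps point in opposite directions: the same change on two cores in this assay, a 2.0-fold lower number (0.31 log units; beyond the scatter) from compound 1 to compound 2 and an at least 18-fold higher number (1.27 log units; beyond the scatter) from compound 3 to compound 4, at least 38-fold (1.58 log units) apart, beyond the scatter of two such steps

Compound 4 gives > 50000 nM, which is a limit of the assay and not a number.

The step on this core is an at least 18-fold higher number from compound 3 to compound 4 (1.27 log units; beyond the scatter), so its true size stays unknown, and two pairs of compounds cannot show why the cores respond so differently.

The compounds shown leave open whether this split belongs to methyl alone or would also appear with a longer chain, a methoxy group or an amine in the same place. They also leave open how either core would respond to a chlorine atom there.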